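The source may report more compounds than this note shows. Statements on the series, on what has been measured and on what is new or still open speak of the compounds shown alone.

In a functional assay on SMMC-7721 cells (Homo sapiens) for antiproliferative activity, read by MTT assay, with a stated time of 48 h (a lower number here means a stronger inhibitor, a higher number a weaker inhibitor), three close relatives sharing one core can be compared. Compound 1 `Cn1cc(C2=C(c3nn(CCCN4CCCCC4)c4ncccc34)C(=O)N(c3ccccc3)C2=O)c2ccccc21` carries piperidin-1-yl on its chain and gives 3050 nM as its value. Compound 2 `Cn1cc(C2=C(c3nn(CCCn4ccnc4)c4ncccc34)C(=O)N(c3ccccc3)C2=O)c2ccccc21` carries 1H-imidazol-1-yl there instead and gives 34800 nM as its value. That swap produces an 11-fold higher number from compound 1 to compound 2 (1.06 log units; beyond the scatter) and is a large change. Compound 3 `Cn1cc(C2=C(c3nn(CCCn4ccnc4)c4ncccc34)C(=O)NC2=O)c2ccccc21` has hydrogen in place of phenyl on the amide-type nitrogen in a ring and gives > 100000 nM as its reading, which is a limit of the assay and not a number. Compound 3 thus stands at the limit of > 100000 nM in this assay, at which 1 of the 3 values shown sits, and has no exact value. The loss of the phenyl produces an at least 2.8-fold higher number from compound 2 to compound 3 (0.45 log units; beyond the scatter) and is at least a modest change.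

Compound 4 `Cn1cc(C2=C(c3nn(CCCCn4ccnc4)c4ncccc34)C(=O)NC2=O)c2ccccc21` differs from compound 3 by (1H-imidazol-1-yl)methyl in place of 1H-imidazol-1-yl on a saturated chain carbon, three bonds along the chain from an aromatic nitrogen and so has (1H-imidazol-1-yl)methyl in place of 1H-imidazol-1-yl on a saturated chain carbon, which turns 3-(1H-imidazol-1-yl)propyl into 4-(1H-imidazol-1-yl)butyl. Neither measured step altered the chain length, so neither sizes this change directly. Compound 4 keeps both features that went with higher numbers, the imidazole group of an 11-fold higher number from compound 1 to compound 2 (1.06 log units; beyond the scatter) and the amide hydrogen of an at least 2.8-fold higher number from compound 2 to compound 3 (0.45 log units; beyond the scatter) as well. The expected step in this assay is a number no higher from compound 3 to compound 4 (the limit leaves the size open) and no shift beyond the scatter is expected. For compound 4 the estimate is 100000 nM with an expected range from 40000 nM to 200000 nM and a reading that may again be only a limit.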

Compound 4, half-maximal inhibitory concentration: 29200 nM
For compound 4 the middle estimate is 3.4-fold (0.53 log units) above the measured one, outside the stated range (below it).
By their numbers in this assay, from the lowest: compound 1; then compounds 4 and 2 (each within the scatter of the next). At a limit, above all of these: compound 3.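

Until now, only the group at the end of the chain and the group on the amide-type nitrogen had changed, and both steps led to higher numbers. Compound 4 shows that the chain length also matters at this position: with the imidazole ring and the amide hydrogen kept, replacing 3-(1H-imidazol-1-yl)propyl with 4-(1H-imidazol-1-yl)butyl gives an at least 3.4-fold lower number from compound 3 to compound 4 (0.53 log units; beyond the scatter) in this assay, so the longer chain moves the number in the opposite direction to those earlier changes. The reading for compound 3 is a limit and not a number, so only the minimum size of this step is known: the limit of > 100000 nM in this assay, at which 1 of the 4 values shown sits.

The compounds shown leave open whether the longer chain would have a similar effect with a phenyl on the amide-type nitrogen or with piperidin-1-yl at the end of the chain. They also leave open how the trend continues with a still longer chain, such as 5-(1H-imidazol-1-yl)pentyl, or with a shorter one, such as 2-(1H-imidazol-1-yl)ethyl.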